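One Substituent Swap, Seen Twice, in a Cytotoxicity Series

The compounds below may be only part of what the source reports. "The series", "measured", "known", "first", "only" and "open" are said of these compounds alone.

Measured compounds:
compound 1 `O=C(Nc1ccc(OC(F)(F)F)cc1)c1cc(F)ccc1O` gives 850 nM
compound 2 `O=C(Nc1ccc(C(F)(F)F)cc1)c1cc(F)ccc1O` gives 490 nM
compound 3 `O=C(Nc1cccc(C(F)(F)F)c1)c1cc(F)ccc1O` gives 970 nM

All three were tested in a functional assay on HL-60 cells (Homo sapiens) for cytotoxicity, read by luminescence and CellTiter-Glo, with a stated time of 3 days; on this read-out higher numbers stand for weaker inhibition and lower numbers for stronger inhibition. The three numbers lie close together; none of the gaps between them exceeds the usual scatter, so nothing can be said about an order among compound 1, compound 2 and compound 3.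

One structural change appears twice. From compound 2 to compound 1 the change is trifluoromethoxy in place of trifluoromethyl on an aromatic carbon, and it produced a 1.7-fold higher number from compound 2 to compound 1 (0.24 log units; within the scatter). The unmeasured compound 4 `O=C(Nc1cccc(OC(F)(F)F)c1)c1cc(F)ccc1O` is related to compound 3 by trifluoromethoxy in place of trifluoromethyl on an aromatic carbon. Compound 2 and compound 3 share the same atoms joined differently; the difference between the two cores is not broken down here. The two swaps are therefore the same kind of change, not the same: in compound 1 the group stands para to a large group, in compound 4 it stands meta to a large group.

For the measured compounds named here, on that basis the step from compound 3 to compound 4 in this assay is expected to be small, much like the earlier one, because the only comparable swap gave a 1.7-fold higher number from compound 2 to compound 1 (0.24 log units; within the scatter). The estimated step is a 1.5-fold higher number from compound 3 to compound 4 (0.19 log units; within the scatter). Compound 4 is expected to give about 1500 nM, with a likely range from 700 nM to 3500 nM.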

Compound 4, half-maximal inhibitory concentration: 730 nM
Beside the measured number, compound 4's estimate is 2.1-fold (0.31 log units) above it; the measured number falls inside the stated range.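

In this assay, putting trifluoromethoxy in place of trifluoromethyl on the core of compound 3 gave a 1.3-fold lower number from compound 3 to compound 4 (0.12 log units; within the scatter). Set beside the earlier case, the new step does not differ from it by more than two such steps would be expected to differ: the same change on two cores in this assay, a 1.7-fold higher number (0.24 log units; within the scatter) from compound 2 to compound 1 and a 1.3-fold lower number (0.12 log units; within the scatter) from compound 3 to compound 4, 2.3-fold (0.36 log units) apart, within the scatter of two such steps The change therefore stayed small on both cores, with neither step beyond the scatter, but the opposite directions of the two steps cannot be read as a real reversal, and two pairs do not show that the change is without effect or that it would stay this small on any further core.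

Every compound shown carries either trifluoromethyl or trifluoromethoxy on the ring that changes, which leaves open how a nitrile, a methoxy group, an amine or a carboxylic acid in that place would read in this assay. Also open, as far as these compounds go, is whether the swap of trifluoromethyl for trifluoromethoxy would remain as small on a core in which the fluorine of the shared core gives way to chlorine, or its hydroxyl to a methoxy group.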